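This account rests on a few compounds, and the source may have more. Where it says the series, first, only, none or still open, it means among the compounds named here.

Measured compounds:
compound 1 `C=C[C@@](C)(/C=C/c1ccc(O)cc1)CC/C=C(C)/C=C/C(=O)OCC` — 815 nM
compound 2 `C=C[C@@](C)(/C=C/c1ccc(O)cc1)CC/C=C(C)/C=C/C(=O)OCc1ccccc1` — 36000 nM
compound 3 `C=C[C@@](C)(/C=C/c1ccc(O)c(/C=C/C(=O)OCC)c1)CCC=C(C)C` — 20900 nM

All three numbers come from a functional assay on NALM-6 cells (Homo sapiens) for cytotoxicity, with a stated time of 72 h; a lower number here means that less compound is needed, a higher number that more compound is needed for the effect. Compound 1 gives 815 nM and is the lowest value of the set. The change from compound 1 to compound 2 is phenyl in place of methyl on a saturated chain carbon bound to an oxygen next to a carbonyl group, and in this assay it made a step of a 44-fold higher number from compound 1 to compound 2 (1.65 log units; beyond the scatter). Compound 3, whose number is 20900 nM, sits nearest to compound 2; the two values lie within the scatter of each other, and compound 3 stands well above compound 1. The difference between the core of compound 1 and the core of compound 3 is not broken down here.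

Compound 4 `C=C[C@@](C)(/C=C/c1ccc(O)c(/C=C/C(=O)OCc2ccccc2)c1)CCC=C(C)C` has not yet been measured. It is related to compound 3 by phenyl in place of methyl on a saturated chain carbon bound to an oxygen next to a carbonyl group, the same change, at the same place in the same words, that led from compound 1 to compound 2. The one worked example is the only ground for an expectation, and it rests on a different core, so how far the step transfers is open. On that basis the step from compound 3 to compound 4 is expected to be a 12-fold higher number from compound 3 to compound 4 (1.08 log units; beyond the scatter). Given that compound 3 already gives 20900 nM, the value for compound 4 is expected to land at 250000 nM, with a likely span from 40000 nM to 1500000 nM.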

Compound 4, half-maximal effective concentration: > 43400 nM
Compound 4 ended at the assay's limit (the forecaster's own chance of this, stated with the estimate: 50%); the middle value lies beyond the limit too.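

Compound 4 gives > 43400 nM in this assay, and this is a limit of the assay, not a number. Phenyl in place of methyl on a saturated chain carbon bound to an oxygen next to a carbonyl group gives an at least 2.0-fold higher number from compound 3 to compound 4 (0.31 log units; beyond the scatter), so the direction of the step seen on the core of compound 1 also holds on the core of compound 3, with the number moving upward on both and the step beyond the scatter on both. The result does not give a size for the step on the second core, so it cannot show whether the change has the same effect on both cores or a larger one on one of them: the same change on two cores in this assay, a 44-fold higher number (1.65 log units; beyond the scatter) from compound 1 to compound 2 and an at least 2.0-fold higher number (0.31 log units; beyond the scatter) from compound 3 to compound 4; the limit leaves it open whether they differ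

The pairs shown cover only one exchange, ethoxycarbonyl to benzyloxycarbonyl, on two cores, so they say nothing about how a longer chain such as butyl, or a carboxylic acid or an amide in place of the ethoxycarbonyl group, would read in this assay. For the compounds shown here, it also remains open whether any such group on either core would give a number lower than the one for compound 1 at 815 nM.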